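Adding a basic side chain to a piperazine-aryl kinase inhibitor

The compounds below may be only part of what the source reports. "The series", "measured", "known", "first", "only" and "open" are said of these compounds alone.

Compound 2 `CCc1n[nH]c2ncnc(N3CCN(c4cc(Cl)ccc4C)CC3)c12` belongs to a small set of three compounds sharing one core and measured in an assay for inhibition of ribosomal protein S6 kinase beta-1 variant D18H,T412E (Homo sapiens), read by a luciferase reporter and chemiluminescence, with a stated time of 3 h; on this read-out lower numbers stand for stronger inhibition and higher numbers for weaker inhibition. In this assay compound 2 gives 6 nM. Compound 3 `CCCc1n[nH]c2ncnc(N3CCN(c4cc(Cl)ccc4C)CC3)c12` gives 6 nM, and compound 2 stands level with it; together they carry the lowest numbers of the three, while compound 1 `Cc1ccc(Cl)cc1N1CCN(c2ncnc3[nH]ncc23)CC1` gives 13 nM, the furthest from compound 2.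

The measured steps all concern the core: a 2.2-fold lower number from compound 1 to compound 2 (0.34 log units; beyond the scatter) and a 2.2-fold lower number from compound 1 to compound 3 (0.34 log units; beyond the scatter) when an alkyl group replaces hydrogen on the core, and no change at the digits printed from compound 2 to compound 3 (within the scatter) when that alkyl is lengthened. Compound 4 `CCc1n[nH]c2ncnc(N3CCN(c4cc(Cl)cc(CCCN(CC)CC)c4C)CC3)c12` instead changes the aryl ring: 3-(diethylamino)propyl in place of hydrogen on an aromatic carbon. Among the compounds with values here, no measured step touches this ring, so the three steps bear on the new change only by showing that the core tolerates small additions; they give no direct guide to a large group on the aryl ring.

The expectation for compound 4 is therefore a step of a 1.3-fold higher number from compound 2 to compound 4 (0.12 log units; within the scatter), close to no change beyond the scatter but with wide uncertainty. The estimate for compound 4 in this assay is 8 nM, within a range from 2 nM to 40 nM.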

Compound 4, half-maximal inhibitory concentration: 3 nM
Compound 4: the middle estimate sits 2.7-fold (0.43 log units) above what was measured, within the range that was stated.
By their numbers in this assay, from the lowest: compounds 4, 2 and 3 (each within the scatter of the next); then compound 1.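

Within the data shown here, this is the first measured change on the aryl ring rather than on the core: in this assay, placing 3-(diethylamino)propyl, with its 8 heavy atoms, on an aromatic carbon ortho to a methyl group and meta to a chloro group gives a 2.0-fold lower number from compound 2 to compound 4 (0.30 log units; within the scatter). The aryl ring therefore accepts a large, flexible chain at this carbon, with the number staying within the scatter of that for compound 2, something the small alkyl changes on the core could not reveal. No evidence is available on how the ring accommodates this chain or what part of the chain matters.

The compounds shown leave open whether the amine in the chain contributes at all or whether the carbon chain alone would give a similar number; a plain butyl group, or a chain ending in a morpholine or a carboxylic acid on the same aromatic carbon, would help separate these possibilities. Also open, from the compounds shown here alone, is whether the same chain would behave alike on the core of compound 1 or compound 3.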